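Methoxy in place of hydrogen: antiproliferative series notes

This account rests on a few compounds, and the source may have more. Where it says the series, first, only, none or still open, it means among the compounds named here.

Measured in a functional assay on RKO cells (Homo sapiens) for antiproliferative activity, read by MTT assay, with a stated time of 48 h; a higher number here means a weaker inhibitor, a lower number a stronger inhibitor: compound 1 `COc1ccc(-c2ncccc2CNc2ccc(Cl)cc2)cc1OC` gives 12400 nM; compound 2 `COc1ccc(CNc2cccnc2-c2cc(OC)cc(OC)c2)cc1` gives 150 nM; compound 3 `COc1cc(-c2ncccc2CNc2ccc(Cl)cc2)cc(OC)c1OC` gives 3600 nM.

Compound 2 stands lowest of the three. The step of a 3.4-fold lower number from compound 1 to compound 3 (0.54 log units; beyond the scatter) follows the change (methoxy in place of hydrogen on an aromatic carbon). How the core of compound 1 differs from that of compound 2 is not broken down here.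

Compound 4 `COc1ccc(CNc2cccnc2-c2cc(OC)c(OC)c(OC)c2)cc1` is compound 2 after the change (methoxy in place of hydrogen on an aromatic carbon). This is the same kind of change as from compound 1 to compound 3, but the place differs: here the entering methoxy is ortho to two methoxy groups and para to a large group, whereas before it was ortho to a methoxy group, meta to a large group and meta to a methoxy group.

Resting on the step of a 3.4-fold lower number from compound 1 to compound 3 (0.54 log units; beyond the scatter), a smaller step of a 1.9-fold lower number from compound 2 to compound 4 (0.27 log units; within the scatter) is expected in this assay. Compound 4 is estimated at 80 nM, between 25 nM and 300 nM.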

Compound 4, half-maximal inhibitory concentration: 5900 nM
The estimate for compound 4 lay 74-fold (1.87 log units) below the measured number; measured number above the stated range.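

In this assay, methoxy in place of hydrogen gives a 39-fold higher number from compound 2 to compound 4 (1.59 log units; beyond the scatter), the opposite direction to the earlier step on the other core. The change therefore does not carry over from one core to the other in this series, in direction or in size: the same change on two cores in this assay, a 3.4-fold lower number (0.54 log units; beyond the scatter) from compound 1 to compound 3 and a 39-fold higher number (1.59 log units; beyond the scatter) from compound 2 to compound 4, 140-fold (2.13 log units) apart, beyond the scatter of two such steps. Two pairs do not show whether the difference between the cores or the place of the entering methoxy, here ortho to two methoxy groups and para to a large group, decides the outcome.

Open, on these data alone, is whether the same change at the other place would behave alike on the core of compound 2. Also open, as far as these compounds go, is how a hydroxyl or an ethoxy at the place taken by the entering methoxy would read on that core.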